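Working notes: compound 3 to compound 4

This account rests on a few compounds, and the source may have more. Where it says the series, first, only, none or still open, it means among the compounds named here.

Measured in a functional assay on cells (Erythrocyte, Rattus norvegicus) for inhibition, read by hemolysis, with a stated time of 1 h; on this read-out higher numbers stand for weaker inhibition and lower numbers for stronger inhibition:
- Compound 1 `COc1cc(OC)c(OC)cc1/C=C/C(=O)c1ccccc1`: 2.23 ug/mL
- Compound 2 `COc1cc(OC)c(OC)cc1/C=C/C(=O)c1ccc(-c2c[nH]cn2)cc1`: 2.48 ug/mL
- Compound 3 `COc1cc(OC)c(OC)cc1/C=C/C(=O)c1ccc(O)cc1O`: 2.37 ug/mL

Compound 3, at 2.37 ug/mL, stands within the scatter of both compound 1 and compound 2, so the three values give it no separate rank.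

The next case is compound 4 `COc1cc(OC)c(OC)cc1/C=C/C(=O)c1ccc(C)cc1`, not yet measured in this assay. The change from compound 3 is 4-methylphenyl in place of 2,4-dihydroxyphenyl on a carbonyl carbon. It puts 4-methylphenyl in place of 2,4-dihydroxyphenyl on a carbonyl carbon.

Going by the values given here, two measured steps bear on this change. The closer one, at the same carbonyl carbon, replaces phenyl with 2,4-dihydroxyphenyl and gives a 1.1-fold higher number from compound 1 to compound 3 (0.03 log units; within the scatter). The other places 1H-imidazol-4-yl on an aromatic carbon and gives a 1.1-fold higher number from compound 1 to compound 2 (0.05 log units; within the scatter). Both steps are small, and the series has so far shown no response to a change on this aromatic group. Among the compounds with values here, no measured compound carries 4-methylphenyl, however, so the data offer no direct test of it.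

No shift beyond the scatter is therefore expected, in either direction. The expected step is a 1.0-fold lower number from compound 3 to compound 4 (0.01 log units; within the scatter). The estimate for compound 4 is 2.3 ug/mL, with an expected range of 1.3 ug/mL to 4 ug/mL.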

Compound 4, half-maximal inhibitory concentration: 2.24 ug/mL
Beside the measured number, compound 4's estimate is 1.0-fold (0.01 log units) above it; the range from low to high includes it.
By their numbers in this assay, from the lowest: compounds 1, 4, 3 and 2 (each within the scatter of the next).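

In this assay the step at the carbonyl carbon gives a 1.1-fold lower number from compound 3 to compound 4 (0.02 log units; within the scatter), so exchanging 2,4-dihydroxyphenyl, with its 2 hydrogen-bond donors and 2 hydrogen-bond acceptors, for 4-methylphenyl, with none of either, leaves the number within the scatter. Methyl on the aromatic carbon gives a 1.0-fold higher number from compound 1 to compound 4 (0.00 log units; within the scatter) when it replaces hydrogen and a 1.1-fold lower number from compound 2 to compound 4 (0.04 log units; within the scatter) when it replaces 1H-imidazol-4-yl , so this read-out does not separate hydrogen, methyl and 1H-imidazol-4-yl at that place. With compound 4 included, the four compounds all lie within the scatter of one another, and none goes against this flat pattern.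

The compounds shown leave open whether any group on this aromatic ring can move the number beyond the scatter, and a primary amine, a carboxylic acid or a longer alkyl chain in place of the methyl of compound 4 would test that. No supporting measurement is available to explain why these exchanges leave the read-out flat.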